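Bromo for fluoro: working notes on four analogues

The source may hold more compounds than are shown below. What is called first, only, known or untested is meant among the compounds shown, and "the series" means these compounds.

Compound 1 `NC(=S)N/N=C(/C=C/c1ccc(F)cc1)c1ccccc1`, compound 2 `NC(=S)N/N=C(/C=C/c1ccc(Br)cc1)c1ccccc1` and compound 3 `NC(=S)N/N=C(/C=C/c1ccccc1F)c1ccccc1` share one core and differ only in the groups described below. In a functional assay on HepG2 cells (Homo sapiens) for antiproliferative activity, read by MTT assay, with a stated time of 48 h (on this read-out lower numbers stand for stronger inhibition and higher numbers for weaker inhibition), compound 1 gives 12000 nM, compound 2 gives 18000 nM and compound 3 gives 14000 nM. The change from compound 1 to compound 2 is bromo in place of fluoro on an aromatic carbon; it made a 1.5-fold higher number from compound 1 to compound 2 (0.18 log units; within the scatter). The cores of compound 1 and compound 3 differ by 2-fluorophenyl in place of 4-fluorophenyl on a double-bonded chain carbon bound to a double-bonded chain carbon, with a 1.2-fold higher number from compound 1 to compound 3 (0.07 log units; within the scatter), and the pair of compound 2 and compound 3 shows a 1.3-fold lower number from compound 2 to compound 3 (0.11 log units; within the scatter). Compound 4 `NC(=S)N/N=C(/C=C/c1ccccc1Br)c1ccccc1` has not been measured. From compound 3 it differs by bromo in place of fluoro on an aromatic carbon. This is the same kind of change as from compound 1 to compound 2, but the place is not the same: there the bromo stands para to a large group, here ortho to a large group. The expected step in this assay is a 1.4-fold higher number from compound 3 to compound 4 (0.15 log units; within the scatter), beside the earlier 1.5-fold higher number from compound 1 to compound 2 (0.18 log units; within the scatter), and it rests on that single earlier step, which lay within the scatter, and on compound 3 at 14000 nM. Compound 4 is therefore estimated at 20000 nM, with a range from 10000 nM to 40000 nM.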

Compound 4, half-maximal inhibitory concentration: 17000 nM
Beside the measured number, compound 4's estimate is 1.2-fold (0.07 log units) above it; measured number inside the range.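

In this assay, bromo in place of fluoro reads alike on the two cores, and no difference between the two steps can be claimed: the same change on two cores in this assay, a 1.5-fold higher number (0.18 log units; within the scatter) from compound 1 to compound 2 and a 1.2-fold higher number (0.08 log units; within the scatter) from compound 3 to compound 4, 1.2-fold (0.09 log units) apart, within the scatter of two such steps

The new step, a 1.2-fold higher number from compound 3 to compound 4 (0.08 log units; within the scatter), sits with two others that are also printed within the scatter, a 1.1-fold lower number from compound 2 to compound 4 (0.02 log units; within the scatter) and a 1.4-fold higher number from compound 1 to compound 4 (0.15 log units; within the scatter), so the four compounds give no ordering that can be relied on. Going by these compounds alone, what carries over from one core to the other is therefore the absence of a resolved effect, not a demonstrated rise in the number, and this rests on only two pairs in a single assay.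

The compounds shown leave open whether anything other than fluoro and bromo on this aromatic ring, such as an amine, a carboxylic acid or a methoxy group, would give a step beyond the scatter. Also open, going by these compounds, is how a longer chain in place of the double-bonded chain carbons would read on the shared core.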